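Swapping the Distal Aryl Group in a Melanocortin Antagonist Series

The compounds below may be only part of what the source reports. "The series", "measured", "known", "first", "only" and "open" are said of these compounds alone.

Measured compounds:
compound 1, `CCN(CC)CCCC(C)/N=C(/N)NC(=O)c1cccc(F)c1OCc1cc(Br)ccc1OC`, 530 nM
compound 2, `CCN(CC)CCCC(C)/N=C(/N)NC(=O)c1cccc(F)c1CCc1cc(Br)ccc1OC`, 130 nM

In a functional assay for antagonist activity at Melanocortin receptor 4 (Homo sapiens), read by cAMP accumulation (on this read-out lower numbers stand for stronger inhibition and higher numbers for weaker inhibition), compound 1 gives 530 nM, and compound 2 gives 130 nM, the lowest of the two numbers. Among the compounds with values here, the only measured step, a 4.1-fold lower number from compound 1 to compound 2 (0.61 log units; beyond the scatter), changed the chain between the two rings, not the ring substituents. Compound 3 `CCN(CC)CCCC(C)/N=C(/N)NC(=O)c1cccc(F)c1CCc1ccccc1Cl` differs from compound 2 by 2-chlorophenyl in place of 5-bromo-2-methoxyphenyl on a saturated chain carbon, two bonds along the chain from an aromatic carbon. Within the data shown here, no measured step tests such a ring swap, so the expectation is uncertain: a step near the scatter, leaning weaker, is estimated as a 1.9-fold higher number from compound 2 to compound 3 (0.28 log units; within the scatter). For compound 3 the expected value is 250 nM, with a range from 70 nM to 900 nM.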

Compound 3, half-maximal inhibitory concentration: > 33000 nM
Compound 3 gave a limit, no number (the forecaster's own chance of this, stated with the estimate: 3%); at least 130-fold (2.12 log units) between middle value and limit.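

In this assay compound 3 gives only a limit of the assay, not a number: the limit of > 33000 nM in this assay, at which 1 of the 3 values shown sits.

Putting 2-chlorophenyl in place of 5-bromo-2-methoxyphenyl on a saturated chain carbon gives an at least 250-fold higher number from compound 2 to compound 3 (2.40 log units; beyond the scatter), so at this position the ring is far from interchangeable, and its change outweighs the earlier chain change. The gap also stays large against the weaker earlier compound, with an at least 62-fold higher number from compound 1 to compound 3 (1.79 log units; beyond the scatter).

The swap changes the bromine, the methoxy and the chlorine together, so the compounds shown do not separate their contributions. On these data alone, how a plain 2-methoxyphenyl or a 5-bromo-2-chlorophenyl ring would read here remains open.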